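The source may report more compounds than this note shows. Statements on the series, on what has been measured and on what is new or still open speak of the compounds shown alone.

The compounds here share one core, a chalcone-type chain linked to an aryl group that carries an imidazolone ring, and were tested in a functional assay on K562 cells (Homo sapiens) for inhibition; a lower number here means a stronger inhibitor of growth, a higher number a weaker inhibitor of growth. Compound 1 `COc1cc(/C=C/C(=O)c2cccc(-n3cc(-c4ccc(Cl)cc4)[nH]c3=O)c2)cc(OC)c1OC` gives 3690 nM. Compound 2 `COc1cc(/C=C/C(=O)c2cccc(-n3cc(-c4ccccc4)[nH]c3=O)c2)ccc1O` gives 2040 nM. Compound 3 `O=C(/C=C/c1cccc(O)c1)c1cccc(-n2cc(-c3ccccc3)[nH]c2=O)c1` gives 3350 nM. On these three numbers compound 3 stands second highest, close to compound 1 and somewhat apart from compound 2, but every gap among them lies within the scatter of repeated measurements.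

Within the data shown here, the only change seen with a measured step is from compound 2 to compound 3, a 3-hydroxyphenyl replacing a 4-hydroxy-3-methoxyphenyl on the chain, which produced a 1.6-fold higher number from compound 2 to compound 3 (0.22 log units; within the scatter).

Compound 4 `O=C(/C=C/c1cccc(O)c1)c1cccc(-n2cc(-c3ccc(Cl)cc3)[nH]c2=O)c1` differs from compound 3 by chloro in place of hydrogen on an aromatic carbon, that is, a chloro group enters on an aromatic carbon of the phenyl ring attached to the imidazolone, para to a large group. Among the measured compounds shown here, no measured pair isolates this change: compound 1, which also carries 4-chlorophenyl, differs from the others at the chain aryl group too, so its value shows only that a chloro-bearing compound sits among the same range of numbers. The step is therefore expected to be small, a 1.0-fold higher number from compound 3 to compound 4 (0.02 log units; within the scatter), with no clear direction beyond the scatter. Compound 4 is estimated at 3500 nM, between 1500 nM and 8000 nM.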

Compound 4, concentration for 50% growth inhibition: 400 nM
Compound 4: the middle estimate sits 8.8-fold (0.94 log units) above what was measured; measured number outside the range, below it.
By their numbers in this assay, from the lowest: compound 4; then compounds 2, 3 and 1 (each within the scatter of the next).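

In this assay, among these compounds, going from phenyl to 4-chlorophenyl, with one chlorine atom entering para to a large group, gives an 8.4-fold lower number from compound 3 to compound 4 (0.92 log units; beyond the scatter), the first step in this set that lies beyond the scatter, so this ring position can respond strongly to a very small change. The 4-chlorophenyl group alone does not guarantee a low number: compound 1 carries it with a different aryl group on the chain and gives 3690 nM, whereas compound 4 gives 400 nM, so the low value appears only with the 3-hydroxyphenyl partner among the compounds shown. No measurement here accounts for the effect of the chlorine on growth inhibition. 

As far as these compounds go, it remains open whether the same position would respond in a similar way to another group, such as fluoro, bromo, methyl or methoxy, or to a basic amine. It is also unknown whether adding chloro to compound 2, which keeps the 4-hydroxy-3-methoxyphenyl group on the chain, would produce a similar step.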